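The compounds below may be only part of what the source reports. "The series", "measured", "known", "first", "only" and "open" are said of these compounds alone.

Measured so far:
Compound 1 `Cc1cccc2c1N(CC(=O)O)C/C(=C\c1ccccc1)C2=O`: 27.9%
Compound 2 `COc1ccc(OC)c(/C=C2\CN(CC(=O)O)c3c(C)cccc3C2=O)c1`: 5.44%

Both compounds were tested in an assay on HL-60 cells for inhibition of glutathione S-transferase P (Homo sapiens), read by spectrophotometry, tested at 20 uM; on this read-out lower numbers stand for less inhibition and higher numbers for more inhibition at the one concentration tested (going by the name of the read-out). Of the two numbers, compound 1 stands highest with 27.9%; its nearest neighbour, compound 2, gives 5.44%, a gap beyond the usual scatter of repeated measurements. Within the data shown here, no pair of measured compounds differs in just one place, so no measured single step is available as a guide.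

Compound 3 `Cc1cccc2c1N(CC(=O)O)C/C(=C\c1ccccc1Cl)C2=O` has not yet been measured. It differs from compound 1 by a single change: chloro in place of hydrogen on an aromatic carbon. Among the measured compounds shown here, with no measured step of this kind to lean on, the expectation rests on compound 1 alone. Small decorations of this sort often leave the read-out much where it was, so the step of a number 2.1 percentage points higher from compound 1 to compound 3 (within the scatter) is expected to be modest, not clearly beyond the scatter, in either direction. Compound 3 is therefore estimated at 30%, with a plausible range from 10% to 55%.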

Compound 3, a percentage reported as inhibition, at one concentration (the size of the read-out at that concentration, not a potency): 51.9%
Beside the measured number, compound 3's estimate is 21.9 percentage points below it; the range from low to high includes it.
By their numbers in this assay, from the lowest: compound 2; then compound 1; then compound 3.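

In this assay, among these compounds, the aromatic ring carried by compound 1 proves sensitive to a very small decoration: going from phenyl to 2-chlorophenyl gives a number 24 percentage points higher from compound 1 to compound 3 (beyond the scatter), the only single change measured so far. A lone chlorine atom on an aromatic carbon, ortho to a large group, is therefore enough to move this read-out clearly, so this position can matter. Nothing available here explains why the chloro group has this effect.

One open question is whether a fluoro group, a methyl group or an amine on the same carbon would shift the number in the same direction. From the compounds shown here alone, it is also open whether chloro on another carbon of this ring would match the step, and compound 2 cannot settle this, as it differs from compound 1 in more than one place.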